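Compound 4: the change at the double-bonded chain carbon

A few compounds are considered here, and "the series" means these few. Any claim that something is new, unique, unknown or untested is made for them only; others in the source may bear on it.

Of the compounds shown here, three have been measured in a functional assay on DU-145 cells (Homo sapiens) for inhibition, read by trypan blue exclusion, with a stated time of 96 h; on this read-out higher numbers stand for weaker inhibition of growth and lower numbers for stronger inhibition of growth. Compound 1 `Cc1ccc(C)c(/C=C(/Sc2ccc(Br)cc2)C(=O)c2ccc(Cl)cc2)c1` gives 10000 nM. Among the measured compounds shown here, compound 2 `Cc1ccc(CS/C(=C/c2cc(C)ccc2C)C(=O)c2ccc(Cl)cc2)cc1` gives 10000 nM, and the single step of no change at the digits printed from compound 1 to compound 2 (within the scatter) shows the sulfur substituent leaving the read-out unchanged. For the measured compounds named here, compound 3 `O=C(O)c1ccc(C(=O)/C(=C\c2ccc(F)c([N+](=O)[O-])c2)SCc2ccc(F)cc2)cc1` gives 1000 nM; it differs from compound 2 in several places at once, so no single step can be drawn between them, and its values show only that it sits at a lower number, beyond the scatter. Compound 2 therefore stands level with compound 1, the two together at the highest number of the three.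

Compound 4 `Cc1ccc(CS/C(=C/c2c[nH]c3ccc(Cl)cc23)C(=O)c2ccc(Cl)cc2)cc1` is still to be measured in this assay. It differs from compound 2 at the double-bonded chain carbon: 5-chloro-1H-indol-3-yl in place of 2,5-dimethylphenyl on a double-bonded chain carbon bound to a double-bonded chain carbon. Going by the values given here, the only measured step, from compound 1 to compound 2, concerns the group on sulfur and says nothing about this carbon, and compound 3 does not isolate it either. Among the compounds with values here, with no step bearing on the change, the expectation is a number near that of compound 2, and the estimated step of a 1.7-fold lower number from compound 2 to compound 4 (0.22 log units; within the scatter) is taken as none beyond the scatter, with a wide range. Compound 4 is thus expected to give 6000 nM, between 1500 nM and 20000 nM.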

Compound 4, concentration for 50% growth inhibition: 1000 nM
Estimate against measurement, compound 4: 6.0-fold (0.78 log units) above; measured number below the stated range.
By their numbers in this assay, from the lowest: compounds 3 and 4 (each within the scatter of the next); then compounds 1 and 2 (each within the scatter of the next).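

In this assay the double-bonded chain carbon is the first position in the series shown to move the read-out beyond the scatter, with 5-chloro-1H-indol-3-yl in place of 2,5-dimethylphenyl (a 10-fold lower number from compound 2 to compound 4 (1.00 log units; beyond the scatter)). Among the compounds shown here, the one earlier step, at the sulfur, showed no such movement (no change at the digits printed from compound 1 to compound 2 (within the scatter)), and compound 3 differs from the others in too many places to isolate this carbon. The group on sulfur and the rest of the core of compound 2 stay fixed in the new step, so the drop in the number belongs to this one exchange, though the exchange brings in a five-membered aromatic ring, a nitrogen with its hydrogen and a chlorine all at once, and no measurement bears on what lies behind the step.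

For the compounds shown here, the single step does not separate these features: a methyl on the ring nitrogen, or a methoxy group in place of the chlorine, would be needed to tell them apart. Also open, going by these compounds, is whether the same exchange holds with the 4-bromophenyl on sulfur of compound 1.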